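Swapping the amine substituent on a shared benzothiazolyl ketone core

The compounds below may be only part of what the source reports. "The series", "measured", "known", "first", "only" and "open" are said of these compounds alone.

Measured compounds:
compound 1 `CC(=O)Nc1ccc(OCCCN2CCC(C(=O)c3nc4ccccc4s3)CC2)cc1` – 7.94 nM
compound 2 `COC(=O)CN1CCC(C(=O)c2nc3ccccc3s2)CC1` – about 100 nM

Of the compounds shown here, two have been measured in a functional assay (ileum) with Cavia porcellus as the target; on this read-out higher numbers stand for weaker binding and lower numbers for tighter binding. Compound 1 `CC(=O)Nc1ccc(OCCCN2CCC(C(=O)c3nc4ccccc4s3)CC2)cc1` gives 7.94 nM in this assay, and compound 2 `COC(=O)CN1CCC(C(=O)c2nc3ccccc3s2)CC1` gives about 100 nM. Of these two numbers, compound 2 holds the higher one, and the gap to compound 1 lies beyond the usual scatter of repeated measurements, so compound 2 is the weaker binder of the pair on this read-out.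

The next compound follows from compound 2 by one change. Compound 3 `COc1cccc(CN2CCC(C(=O)c3nc4ccccc4s3)CC2)c1` differs from compound 2 as follows: 3-methoxyphenyl in place of methoxycarbonyl on a saturated chain carbon bound to an amine nitrogen in a ring. Going by the values given here, no measured pair of compounds shows this particular exchange, so its size must be judged from compound 1 and compound 2 alone, whose values in this assay show that the substituent on the amine nitrogen can move the number a good deal.

On that basis, the step from compound 2 to compound 3 is expected to lower the number, in the direction of compound 1, by a 3.3-fold lower number from compound 2 to compound 3 (0.52 log units; beyond the scatter). Compound 3 is estimated to give 30 nM in this assay, with a plausible range from 8 nM to 150 nM.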

Compound 3, dissociation constant: 50.1 nM
Compound 3: middle estimate off by 1.7-fold (0.22 log units), on the low side; the range from low to high includes it.
By their numbers in this assay, from the lowest: compound 1; then compounds 3 and 2 (each within the scatter of the next).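

In this assay the exchange of methoxycarbonyl for 3-methoxyphenyl on a saturated chain carbon bound to an amine nitrogen in a ring gives a 2.0-fold lower number from compound 2 to compound 3 (0.30 log units; within the scatter) and so cannot be told apart from no change at all. This place therefore accepts 3-methoxyphenyl, with 8 heavy atoms and 1 hydrogen-bond acceptor, as readily as methoxycarbonyl, with 4 heavy atoms and 2 hydrogen-bond acceptors, something compound 1 and compound 2 alone could not show. Nothing available explains why these two groups read alike here.

As far as these compounds go, compound 1 gives 7.94 nM and compound 3 gives 50.1 nM in this assay so the aromatic ring present in compound 3 does not by itself reproduce the printed value of compound 1, and it remains open which part of the longer substituent of compound 1 goes with its number. Also open, from the compounds shown here alone, is whether a plain phenyl without the methoxy group, a carboxylic acid in place of methoxycarbonyl, or a longer chain carrying the 3-methoxyphenyl would move the number beyond the scatter at this place.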